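Swapping an Ether Side Chain for a Small Ring

The compounds below may be only part of what the source reports. "The series", "measured", "known", "first", "only" and "open" are said of these compounds alone.

Within the data shown here, compound 1, `COc1cc(Cc2nc3c(N)ncnc3n2CCOC(C)C)cc(OC)c1OC`, sits at the weak end of the three compounds measured so far. In a functional assay on MCF7 cells (Homo sapiens) for antiproliferative activity (on this read-out lower numbers stand for stronger inhibition and higher numbers for weaker inhibition), compound 1 gives 38900 nM, the highest of the three numbers. Compound 3, `C=CCCn1c(Cc2cc(OC)c(OC)c(OC)c2)nc2c(N)nc(F)nc21`, gives 33100 nM, a value within the usual scatter of that of compound 1, so the two cannot be ranked against each other. Compound 2, `COc1cc(Cc2nc3c(N)nc(F)nc3n2CCOC(C)C)c(Cl)c(OC)c1OC`, gives 5370 nM, clearly lower than compound 1. The unmeasured compound 4, `COc1cc(Cc2nc3c(N)ncnc3n2CC2(C)CC2)cc(OC)c1OC`, differs from compound 1 in one place: 1-methylcyclopropyl in place of isopropoxymethyl on a saturated chain carbon bound to an aromatic nitrogen. Among the measured compounds shown here, no measured pair shows this particular change, so its effect is unknown. The expected step is a 1.3-fold lower number from compound 1 to compound 4 (0.11 log units; within the scatter), no larger than the usual scatter. For compound 4 the estimate is 30000 nM, ranging from 10000 nM to 90000 nM.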

Compound 4, half-maximal inhibitory concentration: 112000 nM
Compound 4: the middle estimate sits 3.7-fold (0.57 log units) below what was measured; the whole stated range lies below it.
By their numbers in this assay, from the lowest: compound 2; then compounds 3 and 1 (each within the scatter of the next); then compound 4.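

In this assay, 1-methylcyclopropyl in place of isopropoxymethyl gives a 2.9-fold higher number from compound 1 to compound 4 (0.46 log units; beyond the scatter), so this side chain does affect the result, and this swap weakens inhibition modestly. The swap removes the ether oxygen, the one hydrogen-bond acceptor in the group, and brings in a three-membered ring, and this single step cannot separate those two differences. Nothing available explains the shift.

As far as these compounds go, whether the oxygen, the ring or the overall shape matters remains open. A 2-methoxyethyl chain or a chain ending in an amine would test this further.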